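This account rests on a few compounds, and the source may have more. Where it says the series, first, only, none or still open, it means among the compounds named here.

Series notes on the shared core of compound 1 `CC1CCN(c2ccc3cc(NC(=O)CCc4ccc(C(F)(F)F)cc4)ccc3n2)C1`. In a functional assay on HEK293 cells for activation of melanin-concentrating hormone receptor 1 (Rattus norvegicus), read by inositol phosphate accumulation (a higher number here means that more compound is needed for the effect, a lower number that less compound is needed), compound 1 gives 400 nM. Compound 2 `O=C(CCc1ccc(C(F)(F)F)cc1)Nc1ccc2nc(N3CCC(c4ccccc4)C3)ccc2c1` gives 1770 nM in this assay, the step being a 4.4-fold higher number from compound 1 to compound 2 (0.65 log units; beyond the scatter). Compound 3 `O=C(CCc1ccc(C(F)(F)F)cc1)Nc1ccc2nc(N3CC4CC3CO4)ccc2c1` gives 70 nM in this assay and stands lowest of the three measured numbers; the steps of a 5.7-fold lower number from compound 1 to compound 3 (0.76 log units; beyond the scatter) and a 25-fold lower number from compound 2 to compound 3 (1.40 log units; beyond the scatter) both point to it, the nearest neighbour being compound 1 and the furthest compound 2.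

Compound 4 `O=C(CCc1ccc(C(F)(F)F)cc1)Nc1ccc2nc(N3CCCCCC3)ccc2c1` differs from compound 3 by a group of 7 heavy atoms (6 carbon, 1 nitrogen; one seven-membered non-aromatic ring with 1 hetero atom) in place of a group of 7 heavy atoms (5 carbon, 1 nitrogen, 1 oxygen; 2 five-membered non-aromatic rings with 1 hetero atom each), on an aromatic carbon. For the measured compounds named here, no measured step leads from the bridged pair of rings to a single seven-membered saturated ring, so the step is judged from the steps into compound 3. The number in this assay is expected to rise for compound 4 because a 5.7-fold lower number from compound 1 to compound 3 (0.76 log units; beyond the scatter) and a 25-fold lower number from compound 2 to compound 3 (1.40 log units; beyond the scatter) show a drop each time the bridged group enters in place of a single saturated ring with one hetero atom, and azepan-1-yl is again such a single ring. Compound 4 is therefore expected near the level of compound 1, estimated at 280 nM (range 90 nM to 900 nM), an expected step of a 4.0-fold higher number from compound 3 to compound 4 (0.60 log units; beyond the scatter).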

Compound 4, half-maximal effective concentration: 1800 nM
Compound 4: the middle estimate sits 6.4-fold (0.81 log units) below what was measured, and the stated range ends below it.
By their numbers in this assay, from the lowest: compound 3; then compound 1; then compounds 2 and 4 (each within the scatter of the next).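

In this assay, the step of a 26-fold higher number from compound 3 to compound 4 (1.41 log units; beyond the scatter) shows that the low number at this position, on the aromatic carbon next to the ring nitrogen, does not follow heavy atom count: azepan-1-yl and the bridged group it replaces each hold 7 heavy atoms. The step of a 4.5-fold higher number from compound 1 to compound 4 (0.65 log units; beyond the scatter) separates azepan-1-yl from 3-methylpyrrolidin-1-yl, whereas the step of a 1.0-fold higher number from compound 2 to compound 4 (0.01 log units; within the scatter) lies within the scatter, so azepan-1-yl and 3-phenylpyrrolidin-1-yl cannot be told apart here. Nothing available bears on the reason for these differences.

Still open, from the compounds shown here alone, is whether the ring oxygen or the bridge goes with the low number of compound 3. Morpholin-4-yl, which has the oxygen without the bridge, and an all-carbon bridged amine, which has the bridge without the oxygen, would separate the two.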